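Mirror-Image Configuration Change on Compound 1

The source may hold more compounds than are shown below. What is called first, only, known or untested is meant among the compounds shown, and "the series" means these compounds.

Compound 1 `O=[N+]([O-])c1ccc(NC(=S)NCCNS(=O)(=O)c2ccc(-c3ccccc3O[C@H]3CC[C@@H](O)CC3)s2)cc1` is examined in a functional assay on RS4-11 cells (Homo sapiens) for inhibition, read by CCK-8 assay, with a stated time of 48 h (a lower number here means a stronger inhibitor, a higher number a weaker inhibitor), where compound 1 gives 9400 nM. Among the numbers shown this is the highest, though the nearest, compound 3 `Cc1ccc(-c2ccsc2S(=O)(=O)NCCNC(=S)Nc2cc(C(F)(F)F)cc(C(F)(F)F)c2)c(Oc2ccc(O)c(O)c2)c1`, gives 4800 nM, a gap that sits within the scatter of such measurements. Compound 2 `COc1cccc(NC(=S)NCCNS(=O)(=O)c2ccc(-c3ccccc3Oc3ccc([N+](=O)[O-])cc3)s2)c1` reaches only a limit of the assay, > 50000 nM (the limit of > 50000 nM in this assay, at which 1 of the 3 values shown sits). The unmeasured compound 4 `O=[N+]([O-])c1ccc(NC(=S)NCCNS(=O)(=O)c2ccc(-c3ccccc3O[C@H]3CC[C@H](O)CC3)s2)cc1` is related to compound 1 by configuration alone: the two compounds have the same atoms and bonds and differ only in configuration as drawn: 2 of 2 stereo elements differ (all stereocentres are inverted: mirror images); a stereocentre at a saturated ring carbon is drawn s in compound 1 and r in compound 4; a stereocentre at a saturated ring carbon is drawn s in compound 1 and r in compound 4. Within the data shown here, no measured pair here shows what such an inversion does, so no direction can be read off; the step from compound 1 to compound 4 is expected to reach no further than the scatter, a 1.1-fold higher number from compound 1 to compound 4 (0.03 log units; within the scatter). Compound 4 is therefore estimated at 10000 nM, within a range from 3500 nM to 30000 nM.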

Compound 4, half-maximal inhibitory concentration: 1500 nM
Compound 4: middle estimate off by 6.7-fold (0.82 log units), on the high side; the whole stated range lies above it.
By their numbers in this assay, from the lowest: compound 4; then compounds 3 and 1 (each within the scatter of the next). At a limit, above all of these: compound 2.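

In this assay configuration alone moves the number (a 6.3-fold lower number from compound 1 to compound 4 (0.80 log units; beyond the scatter)), a step beyond the scatter. Among these compounds, the arrangement at the two saturated ring carbons therefore matters for this series, something no earlier pair could show. The source of the change is narrow: the fact that compounds 1 and 4 differ only in the configuration as drawn.

On these data alone, both stereocentres change together, so the contribution of each one stays open. Also open, as far as these compounds go, is whether an amine in place of the hydroxyl group would keep the lower number seen for compound 4.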